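The source may report more compounds than this note shows. Statements on the series, on what has been measured and on what is new or still open speak of the compounds shown alone.

Among the compounds with values here, in a functional assay on the whole organism (stomach) with Rattus norvegicus as the target (on this read-out higher numbers stand for an effect only at larger amounts of compound and lower numbers for an effect already at smaller amounts), three compounds have numbers so far. Compound 1 (`CCCc1ccc(C(=O)Nc2cc(C(=O)O)cc(C(=O)O)c2)cc1`) gives 94.2 mg/kg on this read-out, compound 2 (`COc1ccc(C(=O)Nc2cc(C(=O)O)cc(C(=O)O)c2)cc1OC`) gives 116 mg/kg and compound 3 (`O=C(O)c1ccc(NC(=O)c2ccc(C(=O)O)cc2)cc1`) gives 54.3 mg/kg in the same test. Compound 1 thus stands among these numbers with both neighbours close by: its distance to compound 2 and its distance to compound 3 each remain within the usual scatter of repeated measurements.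

The next compound is compound 4 (`CCCCc1ccc(C(=O)Nc2cc(C(=O)O)cc(C(=O)O)c2)cc1`), which keeps the core of compound 1 and alters only its chain. The difference is methyl in place of hydrogen on a saturated chain carbon, three bonds along the chain from an aromatic carbon, which turns propyl into butyl.

Within the data shown here, no pair of measured compounds shows a change of this kind, so the data offer no direct guide to it. With so little to go on, no step beyond the scatter is expected in this assay, in either direction. The expected 1.0-fold lower number from compound 1 to compound 4 (0.02 log units; within the scatter) is therefore small. For compound 4 the estimated value is 90 mg/kg, with an expected range from 40 mg/kg to 190 mg/kg in this test.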

Compound 4, dose for 50% inhibition: 91.9 mg/kg
Beside the measured number, compound 4's estimate is 1.0-fold (0.01 log units) below it, and the stated range covers the measured number.
By their numbers in this assay, from the lowest: compounds 3, 4, 1 and 2 (each within the scatter of the next, the first and the last beyond it).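

In this assay, within the data shown here, methyl in place of hydrogen on a saturated chain carbon, three bonds along the chain from an aromatic carbon, turns propyl into butyl and gives a 1.0-fold lower number from compound 1 to compound 4 (0.01 log units; within the scatter) as the first step between measured compounds that differ in one place. The earlier compounds shown here offered no such pair, and this one shows that, on the core of compound 1, the propyl and butyl compounds cannot be told apart on this read-out. No accompanying measurement speaks to what lies behind this result.

This single step describes only one extension at one position, so it leaves open whether a longer chain such as pentyl or hexyl, a shorter one such as ethyl, or a branched chain such as isobutyl would also stay within the scatter of compound 1. It also leaves open whether a chain ending in a hydroxyl group or an amine would be tolerated at this place, and whether the same step from propyl to butyl would read alike on a different core.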